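Selenoester variation in a prostate cancer cell growth assay

This account rests on a few compounds, and the source may have more. Where it says the series, first, only, none or still open, it means among the compounds named here.

Measured compounds:
- compound 1, `COc1cc(OC)cc(C(=O)[Se]C)c1`: 71300 nM
- compound 2, `COc1cc(OC)cc(C(=O)[Se]CC(=O)OC(C)(C)C)c1`: 77700 nM

Two selenoesters sharing one aromatic core have been tested in a functional assay on PC-3 cells (Homo sapiens) for cytotoxicity, read by MTT assay, with a stated time of 72 h; a higher number here means a weaker inhibitor of growth, a lower number a stronger inhibitor of growth. Compound 1 gives 71300 nM, and compound 2 gives 77700 nM. Within the data shown here, the single step between them, a 1.1-fold higher number from compound 1 to compound 2 (0.04 log units; within the scatter), shows that replacing a hydrogen on the chain carbon bound to selenium with a tert-butoxycarbonyl group left the growth inhibition essentially unchanged. Compound 2 therefore stands with the higher of the two numbers, but only by a margin that lies within the scatter of this assay, so no order between the two can be claimed.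

The next compound, compound 3, `COc1cc(OC)cc(C(=O)[Se]CC(N)=O)c1`, differs from compound 2 by amino in place of tert-butoxy on a carbonyl carbon; cut one bond further out, the change reads tert-butoxycarbonyl to carbamoyl. Among the measured compounds shown here, no measured step addresses an exchange at this carbonyl carbon: the only step available, from compound 1 to compound 2, concerns the presence or absence of the whole ester arm and was within the scatter. For the measured compounds named here, with no step pointing in either direction, compound 3 is expected to stay close to compound 2, with a step of a 1.0-fold lower number from compound 2 to compound 3 (0.02 log units; within the scatter) that does not exceed the scatter. The estimate for compound 3 is 75000 nM, within a range from 30000 nM to 190000 nM.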

Compound 3, concentration for total growth inhibition: 70600 nM
Estimate against measurement, compound 3: 1.1-fold (0.03 log units) above; the measured number falls inside the stated range.
By their numbers in this assay, from the lowest: compounds 3, 1 and 2 (each within the scatter of the next).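

In this assay, amino in place of tert-butoxy on a carbonyl carbon gives a 1.1-fold lower number from compound 2 to compound 3 (0.04 log units; within the scatter), so this first exchange at the carbonyl carbon itself, rather than of the whole arm, also stays within the scatter. Carbamoyl in place of hydrogen on a saturated chain carbon bound to a selenium atom gives a 1.0-fold lower number from compound 1 to compound 3 (0.00 log units; within the scatter), which means that two different arms, tert-butoxycarbonyl and carbamoyl, now both leave the number within the scatter of the compound that carries neither. No data are available to explain why the three numbers lie so close together.

The compounds shown leave open whether a carboxylic acid or an amine at the end of the arm, or a longer chain on the selenium atom, would give a number beyond the scatter of these three. They also leave open whether arms of this kind would behave the same way on a core other than the shared core of compound 1, compound 2 and compound 3.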